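This account rests on a few compounds, and the source may have more. Where it says the series, first, only, none or still open, it means among the compounds named here.

Measured so far:
compound 1, `O=C(CCCCCn1cc(Nc2ncc(Cl)c(Nc3ccccc3Cl)n2)cn1)NO` — 630 nM
compound 2, `O=C(CCCCCCn1cc(Nc2ncc(Cl)c(Nc3ccc(Cl)cc3)n2)cn1)NO` — 120 nM
compound 3, `O=C(CCCCCCn1cc(Nc2ncc(Cl)c(Nc3ccccc3)n2)cn1)NO` — 160 nM

In a functional assay on MOLT-4 cells (Homo sapiens) for antiproliferative activity, read by MTT assay, with a stated time of 48 h (a lower number here means a stronger inhibitor, a higher number a weaker inhibitor), compound 1 gives the highest of the three numbers, standing beyond the scatter above both compound 3 and compound 2. Compound 4, `O=C(CCCCCn1cc(Nc2ncc(Cl)c(Nc3ccc(F)cc3)n2)cn1)NO`, is not yet measured. It differs from compound 1 in one place: 4-fluorophenyl in place of 2-chlorophenyl on a nitrogen on an aromatic ring.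

Among the measured compounds shown here, only one measured step bears on this change, and only loosely. Between compound 2 and compound 3 the ring attached to that nitrogen loses its chloro: a 1.3-fold higher number from compound 2 to compound 3 (0.12 log units; within the scatter). That step shows the ring substituent can be removed without a shift beyond the scatter, but it does not test a chloro moved to a different position against a fluoro, and compounds 2 and 3 also differ from compound 1 in a second place, so their gap to compound 1 cannot be read as a single change. For the measured compounds named here, with no direct precedent, the expectation for compound 4 is a step of uncertain size from compound 1, leaning toward a lower number because compound 1 gives 630 nM, the highest seen. Compound 4 is therefore estimated at 400 nM, with a range from 150 nM to 1000 nM, meaning a 1.6-fold lower number from compound 1 to compound 4 (0.20 log units; within the scatter).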

Compound 4, half-maximal inhibitory concentration: 120 nM
Beside the measured number, compound 4's estimate is 3.3-fold (0.52 log units) above it; the whole stated range lies above it.
By their numbers in this assay, from the lowest: compounds 2, 4 and 3 (each within the scatter of the next); then compound 1.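

In this assay, putting 4-fluorophenyl in place of 2-chlorophenyl on the nitrogen gives a 5.3-fold lower number from compound 1 to compound 4 (0.72 log units; beyond the scatter), so the group held at this position can change the antiproliferative reading on an otherwise unchanged structure. Among the compounds shown here, the only earlier step at this position, a 1.3-fold higher number from compound 2 to compound 3 (0.12 log units; within the scatter), stayed within the scatter and so showed no clear effect of the chloro there; the new step is the first change at this position to go beyond the scatter. Nothing available here explains the size of this step.

This single swap changes both the halogen and where it sits on the phenyl ring, so the compounds shown cannot tell whether the identity of the halogen, its location or both together account for the step. Also open, as far as these compounds go, are how an amine or a carboxylic acid on that phenyl ring would read in this assay and whether the same swap would give a similar step on the longer chain carried by compound 2 and compound 3.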